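A Piperazin-1-yl Ring in Place of an Open Chain

The source may report more compounds than this note shows. Statements on the series, on what has been measured and on what is new or still open speak of the compounds shown alone.

In a functional assay on G-361 cells (Homo sapiens) for cytotoxicity, read by fluorescence, with a stated time of 72 h (on this read-out lower numbers stand for stronger inhibition and higher numbers for weaker inhibition), two compounds with a shared core have been measured. Compound 1 (`CC(C)c1n[nH]c2c(NCc3ccc(-c4ccccn4)cc3)nc(N[C@@H]3CCCC[C@H]3N)nc12`) gives 477 nM, and compound 2 (`CC(C)c1n[nH]c2c(NCc3ccc(-c4ccccn4)cc3)nc(NCC(N)CO)nc12`) gives 1020 nM, the higher of the two numbers. Compound 3 (`CC(C)c1n[nH]c2c(NCc3ccc(-c4ccccn4)cc3)nc(N3CCNCC3)nc12`) has not yet been measured. It carries piperazin-1-yl in place of the open chain of compound 2, on an aromatic carbon between two ring nitrogen atoms: a group of 6 heavy atoms (4 carbon, 2 nitrogen; one six-membered non-aromatic ring with 2 hetero atoms) in place of a group of 6 heavy atoms (3 carbon, 2 nitrogen, 1 oxygen; no ring), on an aromatic carbon.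

Among the compounds with values here, only one measured step bears on this change. In that step, a 2.1-fold higher number from compound 1 to compound 2 (0.33 log units; beyond the scatter), 2-amino-3-hydroxypropyl takes the place of 2-aminocyclohexyl on a nitrogen on an aromatic ring. The step is modest, although it does lie beyond the scatter. Within the data shown here, no measured compound yet carries piperazin-1-yl, so this comparison is only a loose guide. Compound 1, which has a ring in its group, sits lower at 477 nM, so a slight move toward lower numbers seems more likely than a rise. The expected change is small and not clearly beyond the scatter: a 1.3-fold lower number from compound 2 to compound 3 (0.11 log units; within the scatter). Compound 3 is estimated at 800 nM, with an expected range from 280 nM to 2300 nM.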

Compound 3, half-maximal inhibitory concentration: 64 nM
The estimate for compound 3 lay 13-fold (1.10 log units) above the measured number; measured number outside the range, below it.
By their numbers in this assay, from the lowest: compound 3; then compound 1; then compound 2.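

In this assay, within the data shown here, the position on the aromatic carbon between two ring nitrogen atoms proves far more responsive than the earlier compounds showed: the only earlier step, a 2.1-fold higher number from compound 1 to compound 2 (0.33 log units; beyond the scatter), was modest, whereas replacing the open chain with piperazin-1-yl gives a 16-fold lower number from compound 2 to compound 3 (1.20 log units; beyond the scatter). A ring in the group does not by itself account for the low number, since compound 1 also carries a ring and the change to piperazin-1-yl still gives a 7.5-fold lower number from compound 1 to compound 3 (0.87 log units; beyond the scatter). No measurement shown here explains why piperazin-1-yl stands apart from the other two groups.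

The compounds shown leave open which feature of piperazin-1-yl matters, and whether a morpholin-4-yl ring, with oxygen in place of the second ring nitrogen, or a piperidin-1-yl ring, with carbon there, would stay near the number of compound 3 at 64 nM. They also do not tell how a methyl group on the free ring nitrogen of piperazin-1-yl would shift the number in this assay.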